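This account rests on a few compounds, and the source may have more. Where it says the series, first, only, none or still open, it means among the compounds named here.

Measured so far:
compound 1, `CCN(CC)C(=O)C(CCO[Si](c1ccccc1)(c1ccccc1)C(C)(C)C)Cn1ccc(=O)[nH]c1=O`: > 100000 nM
compound 2, `CNC(=O)C(CCO[Si](c1ccccc1)(c1ccccc1)C(C)(C)C)Cn1ccc(=O)[nH]c1=O`: > 100000 nM

In an assay on isolated protein for inhibition of Deoxyuridine 5'-triphosphate nucleotidohydrolase, mitochondrial (Homo sapiens), read by spectrophotometry (on this read-out higher numbers stand for weaker inhibition and lower numbers for stronger inhibition), compound 1 gives > 100000 nM, which is a limit of the assay and not a number. Compound 2 in this assay gives > 100000 nM, again a limit, so it stands at the edge of what could be measured. Among the measured compounds shown here, the only measured step, a step that the two limits leave unreadable from compound 1 to compound 2, is therefore of unreadable size, both values sitting at the limit of > 100000 nM in this assay, at which 2 of the 2 values shown sit.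

Compound 3, `CC(C)(C)[Si](OCCC(Cn1ccc(=O)[nH]c1=O)C(N)=O)(c1ccccc1)c1ccccc1`, differs from compound 2 by hydrogen in place of methyl on an amide-type nitrogen. For the measured compounds named here, this resembles the unreadable step, so no step of any readable size is expected; the estimated step is a step that the limit leaves unreadable from compound 2 to compound 3. Compound 3 is expected near 150000 nM, within 30000 nM to 1000000 nM, most likely again only a limit.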

Compound 3, inhibition constant: > 100000 nM
Compound 3: no number, only a limit; the forecaster's own chance of this, stated with the estimate: 80%; the middle value is on the limit's open side.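

Compound 1, compound 2 and compound 3 all sit at one limit and give no number, so no step among them can be read: the limit of > 100000 nM in this assay, at which 3 of the 3 values shown sit.

In this assay the compounds shown leave open how strongly each one inhibits, and whether the groups on the amide-type nitrogen make any difference.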